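Quinoxaline dioxide amines: aliphatic chain in place of aryl

The compounds below may be only part of what the source reports. "The series", "measured", "known", "first", "only" and "open" are said of these compounds alone.

For the measured compounds named here, compound 2 `[O-][n+]1nc(NCOCc2ccc(Cl)cc2)[n+]([O-])c2ccccc21` gives 1470 nM in a functional assay on A549 cells (Homo sapiens) for cytotoxicity, read by MTT assay, with a stated time of 72 h (on this read-out higher numbers stand for weaker inhibition and lower numbers for stronger inhibition), the lowest of the three numbers so far. Compound 1 `COc1ccc2c(c1)[n+]([O-])nc(NCOC(C)c1ccccc1)[n+]2[O-]` gives 3130 nM in this assay and differs from compound 2 in more than one place, so only the two values themselves can be compared. Going by the values given here, compound 3 `[O-][n+]1nc(NCOCc2ccc(C(F)(F)F)cc2)[n+]([O-])c2ccccc21` gives 8420 nM in this assay, and the one single-point step is a 5.7-fold higher number from compound 2 to compound 3 (0.76 log units; beyond the scatter).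

Compound 4 `CC(C)CCOCNc1n[n+]([O-])c2ccccc2[n+]1[O-]` is not yet measured. Against compound 2 the change is isobutyl in place of 4-chlorophenyl on a saturated chain carbon bound to an oxygen on a saturated carbon. Among the compounds with values here, no measured step bears directly on this change: the only step recorded, from compound 2 to compound 3, alters a substituent on the aromatic ring that compound 4 no longer carries. Within the data shown here, the series offers no guide to removing the ring altogether, so the expectation rests on the single observation that the one change made so far at this end of the molecule raised the number. Compound 4 is therefore expected to give 4000 nM in this assay, within 1500 nM to 12000 nM, a step of a 2.7-fold higher number from compound 2 to compound 4 (0.43 log units; beyond the scatter) whose direction is uncertain and whose size may well fall inside the scatter.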

Compound 4, half-maximal inhibitory concentration: 7270 nM
Compound 4: the middle estimate sits 1.8-fold (0.26 log units) below what was measured, within the range that was stated.
By their numbers in this assay, from the lowest: compound 2; then compound 1; then compounds 4 and 3 (each within the scatter of the next).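

In this assay, the aromatic ring can be removed from this end of the molecule without losing a measurable value, though isobutyl in place of 4-chlorophenyl gives a 4.9-fold higher number from compound 2 to compound 4 (0.69 log units; beyond the scatter). Compound 4 at 7270 nM and compound 3 at 8420 nM lie within the scatter of each other, so two different changes to compound 2 end at a similar level, while compound 2 keeps the lowest number of the four. No available evidence accounts for this step.

As far as these compounds go, it remains open whether the ring itself or its chloro substituent matters more, a question that an unsubstituted phenyl at this place would address. Also open, from the compounds shown here alone, is how a cyclohexyl group, a longer chain or a terminal amine would compare with isobutyl here.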